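Swapping the aryl group on a shared core

This account rests on a few compounds, and the source may have more. Where it says the series, first, only, none or still open, it means among the compounds named here.

Of the compounds shown here, two of one series have been measured in a functional assay on MCF7 cells (Homo sapiens) for cytotoxicity, read by MTT assay, with a stated time of 48 h; on this read-out higher numbers stand for weaker inhibition and lower numbers for stronger inhibition. Compound 1 `Cc1ccc(-c2nnc(SCCn3c([N+](=O)[O-])cnc3C)o2)cc1` gives 15500 nM in this assay. Compound 2 `COc1cc(-c2nnc(SCCn3c([N+](=O)[O-])cnc3C)o2)cc(OC)c1OC` gives 30600 nM in this assay. The two numbers lie within the scatter of each other, so neither compound can be set apart from the other on this read-out, and compound 1 stands simply as one of two closely matched values.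

Compound 3 `Cc1ncc([N+](=O)[O-])n1CCSc1nnc(-c2ccccn2)o1` is not yet measured. It differs from compound 1 in one place: pyridin-2-yl in place of 4-methylphenyl on an aromatic carbon. Among the measured compounds shown here, no measured pair in this set shows what such a change does, so any expectation rests on the two values alone. Since compound 1 and compound 2 sit together despite different substituents on that position, compound 3 is expected to stay near them, with a step of a 1.3-fold higher number from compound 1 to compound 3 (0.11 log units; within the scatter) that is expected to be small and in no firm direction. The estimate for compound 3 is 20000 nM, expected to fall between 7000 nM and 60000 nM.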

Compound 3, half-maximal inhibitory concentration: 39100 nM
For compound 3 the middle estimate is 2.0-fold (0.29 log units) below the measured one, within the range that was stated.
By their numbers in this assay, from the lowest: compounds 1, 2 and 3 (each within the scatter of the next, the first and the last beyond it).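

In this assay, among the compounds shown here, the position on the shared core proved sensitive to this change: pyridin-2-yl in place of 4-methylphenyl gives a 2.5-fold higher number from compound 1 to compound 3 (0.40 log units; beyond the scatter), a modest step toward weaker inhibition and the first single-place step. The step exchanges two things at once, since the methyl group leaves and a ring nitrogen enters, and one step cannot separate them. Nothing in hand explains the loss of inhibition.

A plain phenyl group would tell the methyl group and the ring nitrogen apart, and pyridin-3-yl or pyridin-4-yl would show whether the place of that nitrogen in the ring matters. On these data alone, it also remains open whether any group on this position, such as an amine or a carboxylic acid on the phenyl ring, would bring a lower number than compound 1 gives.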